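Swapping a Pentyl Chain for a Phenylethenyl Group

The source may report more compounds than this note shows. Statements on the series, on what has been measured and on what is new or still open speak of the compounds shown alone.

Compound 1, `COc1ccc(Nc2cc(C)oc(=O)c2)cc1`, gives > 30 uM in a functional assay on A549 cells (Homo sapiens) for cytotoxicity, read by MTT assay, with a stated time of 72 h (a lower number here means that less compound is needed, a higher number that more compound is needed for the effect), which is a limit of the assay and not a number.
Compound 2, `COc1ccc(Nc2cc(C3CCCCC3)oc(=O)c2)cc1`, gives 4.62 uM.
Compound 3, `CCCCCc1cc(Nc2ccc(OC)cc2)cc(=O)o1`, gives 4.42 uM.

Compound 3 and compound 2 sit within the scatter of each other, as the step of a 1.0-fold lower number from compound 2 to compound 3 (0.02 log units; within the scatter) shows, so neither can be called the more potent of the two. Compound 1 reports only a limit, (the limit of > 30 uM in this assay, at which 1 of the 3 values shown sits). The two measured steps that leave compound 1 both point the same way: an at least 6.4-fold lower number from compound 1 to compound 2 (0.81 log units; beyond the scatter) and an at least 6.7-fold lower number from compound 1 to compound 3 (0.83 log units; beyond the scatter). In each, a larger carbon group on the ring carbon in place of a small one went with a markedly lower number, while exchanging one larger group for another made no difference beyond the scatter.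

Compound 4, `COc1ccc(Nc2cc(/C=C/c3ccccc3)oc(=O)c2)cc1`, has not yet been measured. It differs from compound 3 by 2-phenylethenyl in place of pentyl on an aromatic carbon. This change again replaces one sizeable carbon group with another, so the steps 2>3 and 1>3 bear on it most directly. A number close to that of compound 3, or somewhat lower, is expected, with no step beyond the scatter being the likeliest outcome.

Compound 4 is therefore estimated at 3 uM in this assay, within a range of 1 uM to 10 uM. The expected step is a 1.5-fold lower number from compound 3 to compound 4 (0.17 log units; within the scatter).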

Compound 4, concentration for half-maximal effect: 0.11 uM
Compound 4: the middle estimate sits 27-fold (1.44 log units) above what was measured; measured number outside the range, below it.
By their numbers in this assay, from the lowest: compound 4; then compounds 3 and 2 (each within the scatter of the next). At a limit, above all of these: compound 1.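

Until now, exchanging one larger carbon group for another on this aromatic carbon next to the ring oxygen changed nothing beyond the scatter in this assay, so a larger group of any kind seemed enough, yet a 40-fold lower number from compound 3 to compound 4 (1.60 log units; beyond the scatter) and a 42-fold lower number from compound 2 to compound 4 (1.62 log units; beyond the scatter) show that the kind of group matters a great deal here. The 2-phenylethenyl group brings a six-membered aromatic ring of carbon only and a double bond outside aromatic rings, neither of which pentyl or cyclohexyl has, although these compounds cannot show which feature goes with the lower number. The widest step is an at least 270-fold lower number from compound 1 to compound 4 (2.43 log units; beyond the scatter) and it rests on a limit, not a number, for compound 1: the limit of > 30 uM in this assay, at which 1 of the 4 values shown sits.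

Going by these compounds, it remains open which part of the 2-phenylethenyl group matters: a saturated 2-phenylethyl chain would test the double bond, and a phenyl group set directly on the ring carbon would test the two-carbon link. Also open, on these data alone, is whether the low number would survive a methoxy group or an amine on the new phenyl ring, or a pyridine ring in its place.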